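Cyclopropyl to Propyl: A Small Change in One Place

The source may report more compounds than this note shows. Statements on the series, on what has been measured and on what is new or still open speak of the compounds shown alone.

Within the data shown here, compound 1 `COc1ncc(-c2ccc3nc(NC(=O)NC4CC4)nn3c2)cc1NS(=O)(=O)c1ccc(F)cc1` is the better of two related compounds tested so far in a functional assay on HCT-116 cells (Homo sapiens) for cytotoxicity, read by MTT assay, with a stated time of 72 h; a higher number here means a weaker inhibitor, a lower number a stronger inhibitor. In this test, compound 1 gives 90 nM, the lowest number on hand. Compound 2 `COc1ncc(-c2ccc3nc(NC(=O)NCCN(C)C)nn3c2)cc1NS(=O)(=O)c1ccc(F)cc1` keeps the same core but carries 2-(dimethylamino)ethyl in place of cyclopropyl on an amide-type nitrogen, and compound 2 gives 220 nM.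

Compound 3 `CCCNC(=O)Nc1nc2ccc(-c3cnc(OC)c(NS(=O)(=O)c4ccc(F)cc4)c3)cn2n1` has not yet been measured. It alters that same place on compound 1: propyl in place of cyclopropyl on an amide-type nitrogen. The cyclopropyl ring gives way to an open propyl chain, and the rest of the molecule stays the same.

Among the measured compounds shown here, the only measured step that bears on this is a 2.4-fold higher number from compound 1 to compound 2 (0.39 log units; beyond the scatter), which is modest but beyond the usual scatter. One step cannot establish a rule, so this guide is thin. Resting on that step, a smaller move towards a higher number, meaning a somewhat weaker inhibitor, is expected here: a 1.4-fold higher number from compound 1 to compound 3 (0.16 log units; within the scatter). For compound 3 the estimated value in this assay is 130 nM, with an expected range from 55 nM to 320 nM.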

Compound 3, half-maximal inhibitory concentration: 150 nM
For compound 3 the middle estimate is 1.2-fold (0.06 log units) below the measured one; the range from low to high includes it.
By their numbers in this assay, from the lowest: compounds 1, 3 and 2 (each within the scatter of the next, the first and the last beyond it).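

In this assay, opening the cyclopropyl ring into a propyl chain of the same 3 carbon atoms gives a 1.7-fold higher number from compound 1 to compound 3 (0.22 log units; within the scatter), so this test cannot tell the ring and the open chain apart at this amide-type nitrogen. The propyl group also cannot be told apart from the group at the other end of the series, as shown by a 1.5-fold lower number from compound 2 to compound 3 (0.17 log units; within the scatter), although the two earlier compounds do differ beyond the scatter, with a 2.4-fold higher number from compound 1 to compound 2 (0.39 log units; beyond the scatter). Compound 3 therefore sits within the scatter of both neighbours, and the three numbers read as a narrow spread in which only the two outer compounds can be separated, while no measurement on hand explains why these groups give these numbers.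

The compounds shown leave open whether a larger ring such as cyclohexyl or a longer chain such as hexyl would stay in this narrow spread. They also leave open what a carboxylic acid or a hydroxyl group at the end of the propyl chain would do to the number at this same place.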